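Chloro Added to the Pyridine Ring of Compound 3

A few compounds are considered here, and "the series" means these few. Any claim that something is new, unique, unknown or untested is made for them only; others in the source may bear on it.

Three compounds of the series have numbers in a functional assay on HFL1 cells for antagonist activity at sphingosine 1-phosphate receptor 2 (Homo sapiens), read by ELISA, with a stated time of 24 h, in the absence of a further agent; a lower number here means a stronger inhibitor, a higher number a weaker inhibitor. Compound 1 `CCOc1nc(Cl)cc2nc(NCc3cc(C)c(-c4cn(C)nc4C)cn3)[nH]c12` gives 2.25 nM. Compound 2 `CCOc1cc(NC(=O)NCc2cc(C)c(-c3cn(C)nc3C(F)(F)F)cn2)cc(Cl)n1` gives 22 nM. Compound 3 `CCOc1cc(NC(=O)NCc2cc(C)c(-c3cn(C)nc3C(F)(F)F)nn2)cc(C)n1` gives 242 nM, the highest of the three numbers; its nearest neighbour is compound 2, whose number lies beyond the scatter below it, and compound 1 lies further below still. Compound 3 is thus the weakest inhibitor among the three measured compounds.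

Compound 4 `CCOc1nc(C)cc(NC(=O)NCc2cc(C)c(-c3cn(C)nc3C(F)(F)F)nn2)c1Cl` differs from compound 3 in one place: chloro in place of hydrogen on an aromatic carbon. The new chloro sits on an aromatic carbon of the six-membered ring with one nitrogen, ortho to the ethoxy group, two atoms from the ring nitrogen and para to the methyl group; the ring changes from 2-ethoxy-6-methylpyridin-4-yl to 3-chloro-2-ethoxy-6-methylpyridin-4-yl. Among the measured compounds shown here, no measured pair isolates this change, so its size is unknown. A small move toward a lower number is expected, within or just beyond the scatter, as a 1.6-fold lower number from compound 3 to compound 4 (0.21 log units; within the scatter). Compound 4 is estimated at 150 nM, with a range from 40 nM to 500 nM.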

Compound 4, half-maximal inhibitory concentration: 26 nM
The estimate for compound 4 lay 5.8-fold (0.76 log units) above the measured number; measured number below the stated range.
By their numbers in this assay, from the lowest: compound 1; then compounds 2 and 4 (each within the scatter of the next); then compound 3.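

In this assay, among the compounds shown here, the change of chloro in place of hydrogen, on the aromatic carbon ortho to the ethoxy group and para to the methyl group, gives a 9.3-fold lower number from compound 3 to compound 4 (0.97 log units; beyond the scatter) and is the only single-place step so far. For the compounds shown here, this position therefore responds to a single added heavy atom, with a step beyond the scatter, which the earlier compounds, differing in more than one place, could not show. No measurement at hand accounts for the size of this step.

As far as these compounds go, whether a fluoro, bromo, methyl or methoxy group on the same carbon would give a similar step remains open. From the compounds shown here alone, it is also open whether chloro at this position would give a comparable step on the core of compound 1 or compound 2.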